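Chain branching on the carboxy sulfonamide anilines

The source may hold more compounds than are shown below. What is called first, only, known or untested is meant among the compounds shown, and "the series" means these compounds.

Compound 3 `CCCCNc1ccc(C(=O)O)cc1S(N)(=O)=O` carries a butyl chain on the ring nitrogen, a free sulfonamide and a carboxy group. In an assay on HEK293 cells for inhibition of solute carrier family 12 member 2 (Homo sapiens), read by fluorescence, with a stated time of 30 min, tested at 100 uM (on this read-out higher numbers stand for a stronger effect at the one concentration tested and lower numbers for a weaker effect), compound 3 gives 6.4%. Among the three compounds measured it has the highest number, but the margins are small: compound 2 `CCCCCCNc1ccc([N+](=O)[O-])cc1S(=O)(=O)N(C)C` gives 4.9% and compound 1 `CCCCNc1ccc([N+](=O)[O-])cc1S(N)(=O)=O` gives 4.7%, both within the usual scatter of compound 3. Among the measured compounds shown here, the one single-point step on record, a number 1.7 percentage points higher from compound 1 to compound 3 (within the scatter), is itself within the scatter; compound 1 and compound 2 differ in two places, so their values are only read side by side and show no separation either.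

Compound 4 `CC(C)(C)CCNc1ccc(C(=O)O)cc1S(N)(=O)=O` is the next member: tert-butyl in place of ethyl on a saturated chain carbon, two bonds along the chain from a nitrogen on an aromatic ring. For the measured compounds named here, no measured step touches this part of the molecule, so the branching has no precedent here. What the series does show is that all three measured numbers sit in the same low band, regardless of the group on the aromatic carbon or the sulfonamide substitution. The expectation is therefore a step of a number 0.4 percentage points lower from compound 3 to compound 4 (within the scatter) in this assay, no change beyond the scatter. Compound 4 is estimated at 6%, with a range from -2% to 15%.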

Compound 4, a percentage reported as inhibition, at one concentration (the size of the read-out at that concentration, not a potency): 5.1%
Compound 4: middle estimate off by 0.9 percentage points, on the high side, and the stated range covers the measured number.
By their numbers in this assay, from the lowest: compounds 1, 2, 4 and 3 (each within the scatter of the next).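

Tert-butyl in place of ethyl on a saturated chain carbon, two bonds along the chain from a nitrogen on an aromatic ring, is the first change tested at this position, and this assay gives a number 1.3 percentage points lower from compound 3 to compound 4 (within the scatter) for this replacement. The butyl chain and the 3,3-dimethylbutyl chain are therefore not separated on this read-out, so branching at the chain end, with the added carbons counted for tert-butyl, does not lift the series out of its low band. No measurement available bears on why the step came out this way.

As far as these compounds go, with all the numbers in that low band, it remains open whether any other group at the chain end, such as a terminal amine, a hydroxyl or a phenyl ring in place of tert-butyl, would give a step beyond the scatter. Also open, from the compounds shown here alone, is whether a longer straight chain on the shared core would do so, or whether the same branching would read alike with a nitro group in place of the carboxy group.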